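From compound 1 to compound 3: an added ethyl

The source may hold more compounds than are shown below. What is called first, only, known or untested is meant among the compounds shown, and "the series" means these compounds.

Measured so far in an ADME assay on Caco-2 cells (Homo sapiens) for permeability, read by HPLC, in the apical to basolateral direction, with a stated time of 60 min, at pH 6.5, tested at 10 uM; on this read-out higher numbers stand for higher permeability and lower numbers for lower permeability:
Compound 1 `O=C(O)Cc1nn(Cc2cn3cc(OCC4CC4)c(Cl)cc3n2)c2ccccc2c1=O`: 0.8 10^-6 cm/s
Compound 2 `CC(C(=O)O)c1nn(Cc2cn3cc(OCC4CC4)c(C(F)(F)F)cc3n2)c2ccccc2c1=O`: 15 10^-6 cm/s

Of these two, compound 1 has the lower number, and its gap to compound 2 lies beyond the usual scatter. Compound 3 `CCC(C(=O)O)c1nn(Cc2cn3cc(OCC4CC4)c(Cl)cc3n2)c2ccccc2c1=O` has not yet been measured. It turns the carboxymethyl of compound 1 into 1-carboxypropyl, with ethyl in place of hydrogen on a saturated chain carbon bound to an aromatic carbon and a carbonyl carbon. Among the measured compounds shown here, no measured pair shows this change alone. The only hint is the higher number of compound 2 at 15 10^-6 cm/s, a loose guide, since that compound is no single-change neighbour of compound 1. In this assay, an upward move beyond the scatter is expected, an estimated 5.0-fold higher number from compound 1 to compound 3 (0.70 log units; beyond the scatter). For compound 3 the estimated value is 4 10^-6 cm/s, with an expected range from 1.2 10^-6 cm/s to 12 10^-6 cm/s.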

Compound 3, apparent permeability: 17 10^-6 cm/s
Compound 3: the middle estimate sits 4.3-fold (0.63 log units) below what was measured; the whole stated range lies below it.
By their numbers in this assay, from the lowest: compound 1; then compounds 2 and 3 (each within the scatter of the next).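

Read in this assay this is the first single-change comparison at the saturated chain carbon bound to an aromatic carbon and a carbonyl carbon. Ethyl in place of hydrogen there gives a 21-fold higher number from compound 1 to compound 3 (1.33 log units; beyond the scatter) with the rest of the molecule unchanged. This shows that a change at this one place can by itself produce a large step beyond the usual scatter, although no measurement here accounts for the rise.

As far as these compounds go, whether the size of the step is specific to ethyl remains open, and a propyl chain or a hydroxyl group on the same carbon would test this. A single step on a single core also cannot show whether ethyl would give a similar step with different groups elsewhere in the molecule.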